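The source may report more compounds than this note shows. Statements on the series, on what has been measured and on what is new or still open speak of the compounds shown alone.

Three compounds sharing one core have been measured:
- compound 1 `CC(C)=CCC1Cc2c(OC(=O)Nc3cccc(C(F)(F)F)c3)cc(=O)n(CCCO)c2CC1(C)C`: 0%
- compound 2 `COc1cccc(NC(=O)Oc2cc(=O)n(CCCO)c3c2CC(C/C=C(\C)CCC=C(C)C)C(C)(C)C3)c1`: 11.3%
- compound 3 `CC(C)=CCC/C(C)=C/CC1Cc2c(OC(=O)Nc3ccc(F)c(F)c3)cc(=O)n(CCCO)c2CC1(C)C`: 4.8%

All three were tested in a functional assay on PANC-1 cells (Homo sapiens) for inhibition, read by MTT assay, with a stated time of 24 h, tested at 10 uM; a lower number here means less inhibition, a higher number more inhibition at the concentration tested (going by the name of the read-out). In this assay compound 1 gives 0%, compound 2 gives 11.3% and compound 3 gives 4.8%. On these numbers compound 3 sits between the other two, yet its gap to each of them is within the scatter, so the three compounds cannot really be told apart here. Within the data shown here, the one single-change step among them, a number 6.5 percentage points lower from compound 2 to compound 3 (within the scatter), is also within the scatter.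

Compound 4 `CC(C)=CCC/C(C)=C/CC1Cc2c(OC(=O)Nc3cccc(C(F)(F)F)c3)cc(=O)n(CCCO)c2CC1(C)C` is compound 3 with one change: 3-(trifluoromethyl)phenyl in place of 3,4-difluorophenyl on an amide-type nitrogen. Among the measured compounds shown here, no measured step reproduces this exact swap. Compound 4 shares its 3-(trifluoromethyl)phenyl group with compound 1, whose chain differs; in this assay compound 1 gives 0%, as low as the rest. For the measured compounds named here, the only swap of the aryl group that was measured, a number 6.5 percentage points lower from compound 2 to compound 3 (within the scatter), left the number within the scatter, and every compound so far shows little inhibition. The expected step is therefore a number 2.8 percentage points lower from compound 3 to compound 4 (within the scatter), nothing beyond the scatter. Compound 4 is estimated at 2%, within a range from 0% to 12%.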

Compound 4, a percentage reported as inhibition, at one concentration (the size of the read-out at that concentration, not a potency): 6.7%
For compound 4 the middle estimate is 4.7 percentage points below the measured one, within the range that was stated.
By their numbers in this assay, from the lowest: compounds 1, 3, 4 and 2 (each within the scatter of the next, the first and the last beyond it).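

Putting 3-(trifluoromethyl)phenyl in place of 3,4-difluorophenyl on the amide-type nitrogen gives in this assay a number 1.9 percentage points higher from compound 3 to compound 4 (within the scatter), so these two aryl groups cannot be told apart by this read-out. The third pairing at this position, trifluoromethyl in place of methoxy on an aromatic carbon, gives a number 4.6 percentage points lower from compound 2 to compound 4 (within the scatter), which means that all three aryl groups carried with this longer chain now stand within the scatter of one another, and no preference among them can be claimed. Among these compounds, compound 4 also provides the first comparison in which the aryl group stays fixed and only the chain changes: 3-methylbut-2-en-1-yl in place of hydrogen on a saturated chain carbon gives a number 6.7 percentage points higher from compound 1 to compound 4 (within the scatter), so this extension of the chain shows no separable effect either.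

Nothing available offers an explanation for these numbers. Going by these compounds, it remains open whether a more different group on the amide-type nitrogen, such as a phenyl ring carrying a carboxylic acid or an amine, or a chain longer than that of compound 4, would move the number beyond the scatter.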